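From 2-methylphenyl to 3-methoxyphenyl at the assay limit

The source may hold more compounds than are shown below. What is called first, only, known or untested is meant among the compounds shown, and "the series" means these compounds.

Values measured in an ADME assay on MDBK cells (Bos taurus) for cytotoxicity (on this read-out higher numbers stand for lower toxicity in this test and lower numbers for higher toxicity in this test), each of them a limit of the assay and not a number:
- Compound 1 `Cc1ccn(Cc2c(F)cccc2F)c2nc(-c3c(F)cccc3F)nc1-2`: > 100000 nM
- Compound 2 `Fc1cccc(F)c1-c1nc2ccn(Cc3ccccc3)cc-2n1`: > 100000 nM
- Compound 3 `Cc1ccccc1Cn1ccc2nc(-c3ccccc3)nc-2c1`: > 100000 nM

In this assay compound 3 stands at > 100000 nM, which is a limit and not a number. Among the compounds with values here, it has company there, as the series so far shows (the limit of > 100000 nM in this assay, at which 3 of the 3 values shown sit). No number has yet been obtained for any of the three compounds.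

Compound 4 `COc1cccc(Cn2ccc3nc(-c4ccccc4)nc-3c2)c1` carries 3-methoxyphenyl in place of 2-methylphenyl on a saturated chain carbon bound to an aromatic nitrogen. Within the data shown here, no measured pair of compounds shows what a single change does here. The expectation therefore rests on compound 3, whose > 100000 nM is a limit. No step beyond the scatter is expected in this assay, and the estimated a number no higher from compound 3 to compound 4 (the limit leaves the size open) should be read in that light. Compound 4 is expected to give 100000 nM, with an estimated range of 40000 nM to 250000 nM.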

Compound 4, half-maximal cytotoxic concentration: > 100000 nM
Compound 4 gave a limit, no number; the forecaster's own chance of this, stated with the estimate: 80%; the middle value lies on the limit itself.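

Compound 3 and compound 4 each give only a limit in this assay, so no step can be read between them. The compounds shown leave open what number any of them would give, and what 3-methoxyphenyl in place of 2-methylphenyl does to it: the limit of > 100000 nM in this assay, at which 4 of the 4 values shown sit.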